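The source may hold more compounds than are shown below. What is called first, only, known or untested is meant among the compounds shown, and "the series" means these compounds.

Measured so far:
- compound 1, `CCCCCn1c(-c2ccco2)nc2c(NCCCOC)ccnc21`, 34200 nM
- compound 2, `CCCCCn1c(-c2ccco2)nc2c(NCCCO)ccnc21`, 63600 nM
- compound 3, `COCCCNc1nccc2c1nc(-c1ccco1)n2C1CCCC1`, 142000 nM

These three were tested in an assay on isolated protein for inhibition of high affinity 3',5'-cyclic-AMP phosphodiesterase 7A (Homo sapiens), read by cAMP accumulation, with a stated time of 20 min; on this read-out higher numbers stand for weaker inhibition and lower numbers for stronger inhibition. Compound 1 and compound 2 share one core and differ in one place only; the difference is hydrogen in place of methyl on an oxygen on a saturated carbon. Across this change the read-out moved by a 1.9-fold higher number from compound 1 to compound 2 (0.27 log units; within the scatter), so the two values cannot be told apart with confidence. Compound 3 has a different core, and the difference between the two cores is not broken down here. Compound 3 gives the highest number of the three, beyond the scatter from both compound 1 and compound 2.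

Compound 4, `OCCCNc1nccc2c1nc(-c1ccco1)n2C1CCCC1`, is not yet measured. It relates to compound 3 exactly as compound 2 relates to compound 1: the difference is hydrogen in place of methyl on an oxygen on a saturated carbon, at a place described in the same words, so the same change is being made on the core of compound 3. Because the earlier step was a 1.9-fold higher number from compound 1 to compound 2 (0.27 log units; within the scatter), a step of similar size is expected here, about a 1.8-fold higher number from compound 3 to compound 4 (0.26 log units; within the scatter). Compound 4 is therefore estimated to give 260000 nM in this assay, with a likely range from 110000 nM to 600000 nM.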

Compound 4, half-maximal inhibitory concentration: > 200000 nM
Compound 4: only a limit was reported; the forecaster's own chance of this, stated with the estimate: 35%; the middle value does not contradict the limit.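

In this assay compound 4 gives > 200000 nM, which is a limit of the assay and not a measured number. On the second core, putting hydrogen in place of methyl on an oxygen on a saturated carbon gives an at least 1.4-fold higher number from compound 3 to compound 4 (0.14 log units; that floor lies within the scatter), so only a smallest possible size of the step can be read, and the comparison with the first core goes only this far: the same change on two cores in this assay, a 1.9-fold higher number (0.27 log units; within the scatter) from compound 1 to compound 2 and an at least 1.4-fold higher number (0.14 log units; that floor lies within the scatter) from compound 3 to compound 4; the limit leaves it open whether they differ. The result fits the change carrying over from one core to the other in the same direction, but it does not show that the two steps match in size, and neither printed figure lies beyond the scatter.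

From the compounds shown here alone, how large the step on the second core really is stays open, as the limit gives no value to set against the first core. Going by these compounds, all four compounds end their chain in methoxy or hydroxy, so it also stays open how an amine, a carboxylic acid or a longer chain would read on either core.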